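The source may report more compounds than this note shows. Statements on the series, on what has been measured and on what is new or still open speak of the compounds shown alone.

Compound 1, `c1ccc2c(c1)CN[C@@H](CN(CCCCN(Cc1ccncc1)Cc1ccncc1)[C@H]1CCCc3cccnc31)C2`, gives 832 nM in a functional assay on cells for antagonist activity at C-X-C chemokine receptor type 4 (Homo sapiens), read by fluorescence and calcium flux, with stated times of 25 min and 90 s; on this read-out higher numbers stand for weaker inhibition and lower numbers for stronger inhibition.
Compound 2, `c1ccc(CNCCCCN(C[C@H]2Cc3ccccc3CN2)[C@H]2CCCc3cccnc32)cc1`, gives 20.1 nM in this assay.

Of the two numbers, compound 2 holds the lower one, and its gap to compound 1 lies beyond the scatter. Compound 3, `CC(C)(CCN)CN(C[C@H]1Cc2ccccc2CN1)[C@H]1CCCc2cccnc21`, has not yet been measured. Compared with compound 2 it carries a group of 6 heavy atoms (5 carbon, 1 nitrogen; no ring) in place of a group of 11 heavy atoms (10 carbon, 1 nitrogen; one six-membered aromatic ring of carbon only), on a saturated chain carbon bound to an amine nitrogen. Among the compounds with values here, no step between measured compounds of this kind is at hand, so the expectation rests on compound 2 alone. In this assay the step of a 3.5-fold higher number from compound 2 to compound 3 (0.54 log units; beyond the scatter) is expected to be modest and toward a higher number, because compound 2 sits at 20.1 nM and the change removes a good part of the group. Compound 3 is therefore estimated at 70 nM, within 15 nM to 350 nM.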

Compound 3, half-maximal inhibitory concentration: > 33300 nM
Compound 3 gave a limit, no number (the forecaster's own chance of this, stated with the estimate: 3%); middle value at least 470-fold (2.67 log units) from the limit.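

In this assay compound 3 gives only a limit of the assay, not a number: the limit of > 33300 nM in this assay, at which 1 of the 3 values shown sits. At this place, on a saturated chain carbon bound to an amine nitrogen, exchanging 3-(benzylamino)propyl for the smaller group with no ring gives an at least 1600-fold higher number from compound 2 to compound 3 (3.21 log units; beyond the scatter). The two groups match in hydrogen-bond donors, acceptors and net charge, so these counts do not separate them, while the aromatic ring and the size do differ. The compounds shown leave open whether the ring or the chain carries this step, and how a cyclohexylmethyl amine or a longer chain would read here.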